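From 4-bromophenyl to 2-fluorophenyl in compound 4

This account rests on a few compounds, and the source may have more. Where it says the series, first, only, none or still open, it means among the compounds named here.

In an ADME assay on Vero cells (Chlorocebus sabaeus) for inhibition (on this read-out higher numbers stand for lower toxicity in this test and lower numbers for higher toxicity in this test), compound 1 `COc1ccc(/C=C2\CCC/C(=C\c3ccc(OC)cc3)C2=O)cc1` gives 178000 nM, compound 2 `COc1ccc(/C=C2\CCC/C(=C\c3ccccc3)C2=O)cc1` gives 291000 nM, and compound 3 `COc1ccc(/C=C2\CCC/C(=C\c3ccc(Br)cc3)C2=O)cc1` gives 250000 nM. These three values cannot be told apart, so compound 3 stands level with the other two within the scatter of repeated measurements.

Compound 4 `COc1ccc(/C=C2\CCC/C(=C\c3ccccc3F)C2=O)cc1` changes one group of compound 3: 2-fluorophenyl in place of 4-bromophenyl on a double-bonded chain carbon bound to a double-bonded ring carbon. In words, 2-fluorophenyl sits in place of 4-bromophenyl on a double-bonded chain carbon bound to a double-bonded ring carbon.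

The measured steps that bear on this swap are those that change the group on that same ring: a 1.6-fold higher number from compound 1 to compound 2 (0.21 log units; within the scatter), a 1.4-fold higher number from compound 1 to compound 3 (0.15 log units; within the scatter) and a 1.2-fold lower number from compound 2 to compound 3 (0.07 log units; within the scatter). All three are small and lie within the scatter. However, no measured compound carries 2-fluorophenyl, so the range must stay wide.

The expected change is a 1.0-fold lower number from compound 3 to compound 4 (0.02 log units; within the scatter), which means no step beyond the scatter is anticipated. Compound 4 is estimated at 240000 nM, with an expected range from 130000 nM to 420000 nM.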

Compound 4, half-maximal cytotoxic concentration: 270000 nM
Compound 4: the middle estimate sits 1.1-fold (0.05 log units) below what was measured, within the range that was stated.
By their numbers in this assay, from the lowest: compounds 1, 3, 4 and 2 (each within the scatter of the next).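

In this assay, placing 2-fluorophenyl on a double-bonded chain carbon bound to a double-bonded ring carbon leaves the number within the scatter of all three earlier compounds (a 1.1-fold higher number from compound 3 to compound 4 (0.03 log units; within the scatter); a 1.1-fold lower number from compound 2 to compound 4 (0.03 log units; within the scatter); a 1.5-fold higher number from compound 1 to compound 4 (0.18 log units; within the scatter)). The earlier compounds shown here carried only 4-methoxyphenyl, 4-bromophenyl or an unsubstituted ring at this place, so compound 4 extends the set to a fluoro group and to a substituent at the 2 rather than the 4 of the ring, and still no step rises beyond the scatter. Nothing available here accounts for this lack of change.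

As far as these compounds go, it remains open whether an amine or a carboxylic acid on this ring would give a step beyond the scatter. A longer chain in place of the ring is equally untested by the compounds shown here.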